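The source may hold more compounds than are shown below. What is called first, only, known or untested is meant among the compounds shown, and "the series" means these compounds.

Compound 1 `COc1ccc(C2N=C(SCc3ccccc3)NC(C)=C2C(=O)Nc2ccc(F)cc2)cc1OC` and compound 2 `COc1ccc(C2N=C(SCc3ccccc3Cl)NC(C)=C2C(=O)Nc2ccc(F)cc2)cc1OC` share one core and differ only in a chloro in place of a hydrogen on an aromatic carbon. Within the data shown here, in a functional assay on the whole organism (artery, strain albino) with Rattus norvegicus as the target, with a stated time of 360 min, at a dose of 10 mg/kg by the oral route (on this read-out lower numbers stand for less inhibition and higher numbers for more inhibition at the one dose given (going by the name of the read-out)), compound 1 gives 3.6%, and compound 2 gives 39.2%; the step of a number 35.6 percentage points higher from compound 1 to compound 2 (beyond the scatter) is the only measured step, and it places compound 2 highest of the two numbers, with compound 1 as its nearest neighbour.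

Compound 3 `COc1ccc(C2N=C(SCc3cccc(Cl)c3)NC(C)=C2C(=O)Nc2ccc(F)cc2)cc1OC` is not yet measured. It differs from compound 2 by 3-chlorophenyl in place of 2-chlorophenyl on a saturated chain carbon bound to a sulfur. Among the measured compounds shown here, no measured step bears directly on this change: the step from compound 1 to compound 2 adds a chlorine, whereas here the chlorine only moves from one aromatic carbon to another. Compound 2 therefore serves as the anchor, and the expected step of a number 9.2 percentage points lower from compound 2 to compound 3 (within the scatter) is small and uncertain in direction. Compound 3 is estimated to give 30% in this assay, within a range of 5% to 55%.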

Compound 3, a percentage reported as inhibition, in the whole organism at one dose (the size of the read-out at that dose, not a potency): 20.1%
Compound 3: the middle estimate sits 9.9 percentage points above what was measured; the range from low to high includes it.
By their numbers in this assay, from the lowest: compound 1; then compound 3; then compound 2.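

Moving the chlorine, with the atoms unchanged, matters as well as its presence in this assay: 3-chlorophenyl in place of 2-chlorophenyl on a saturated chain carbon bound to a sulfur gives a number 19.1 percentage points lower from compound 2 to compound 3 (beyond the scatter) and so the two placements are not interchangeable. The chloro still counts in its new place, with a number 16.5 percentage points higher from compound 1 to compound 3 (beyond the scatter) as the gain over the unsubstituted benzyl group, so both chlorinated compounds stand above compound 1 and the 2-chlorophenyl group gives the larger gain. Nothing available explains why the two placements differ.

On these data alone, whether a bromo or a nitrile in place of the chloro would follow the same order stays open. These numbers also come from a single oral dose, so they leave the dose response of all three compounds unsettled.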